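The compounds below may be only part of what the source reports. "The series", "measured", "known", "first", "only" and "open" are said of these compounds alone.

In a functional assay on cells (Leukemia cell, Homo sapiens) for inhibition (a lower number here means a stronger inhibitor of growth, a higher number a weaker inhibitor of growth), compound 1 `Cc1cn2c(/C=N/NC(=N)N)c(-c3ccsc3)nc2s1` gives 7760 nM and compound 2 `N=C(N)N/N=C/c1c(-c2ccsc2)nc2sccn12` gives 6920 nM, so the two stand within the scatter of each other. The change to compound 3 `Cc1cn2c(/C=N/NC(=N)N)c(-c3cccs3)nc2s1` is thiophen-2-yl in place of thiophen-3-yl on an aromatic carbon. Within the data shown here, the only measured step, a 1.1-fold lower number from compound 1 to compound 2 (0.05 log units; within the scatter), is a methyl change that leaves thiophen-3-yl untouched, so it is only indirect evidence for this swap. No shift beyond the scatter is expected in this assay, and the estimated step is a 1.1-fold lower number from compound 1 to compound 3 (0.04 log units; within the scatter). Compound 3 is estimated at 7000 nM, with an expected range of 3500 nM to 14000 nM.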

Compound 3, concentration for 50% growth inhibition: 1820 nM
The estimate for compound 3 lay 3.8-fold (0.59 log units) above the measured number, and the stated range ends above it.
By their numbers in this assay, from the lowest: compound 3; then compounds 2 and 1 (each within the scatter of the next).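

In this assay, the point of attachment of the thiophene on this aromatic carbon affects growth inhibition, although the atoms stay the same: thiophen-2-yl in place of thiophen-3-yl gives a 4.3-fold lower number from compound 1 to compound 3 (0.63 log units; beyond the scatter). Among these compounds, this is the first step beyond the scatter, and it shows that this position responds to a change that the methyl step left untested. Nothing available here accounts for the difference. Open, on these data alone, is whether thiophen-2-yl keeps this advantage with hydrogen in place of methyl, and whether a phenyl or furan-2-yl group on this carbon would match it.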